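Extending the amide arm of compound 1 by two carbons

The source may report more compounds than this note shows. Statements on the series, on what has been measured and on what is new or still open speak of the compounds shown alone.

Compound 1, with the structure `Nc1ccccc1NC(=O)c1ccc(Cn2cnc3c(Nc4ccccc4)nc(Cl)nc32)cc1`, is the point of departure. In a functional assay on HCT-116 cells (Homo sapiens) for antiproliferative activity, read by CCK-8 assay, with a stated time of 72 h, tested at 8 uM (a higher number here means a stronger effect of the compound at the concentration tested, a lower number a weaker effect), compound 1 gives 83.5%, the highest of the three numbers measured. Compound 2, `Nc1ccccc1NC(=O)c1ccc(Cn2cnc3c(Nc4ccc(-c5ccccn5)cc4)nc(Cl)nc32)cc1`, gives 73.7%, and the step of a number 9.8 percentage points lower from compound 1 to compound 2 (within the scatter) lies within the usual scatter, so the two numbers cannot be told apart. Compound 3, `Nc1ccccc1NC(=O)c1ccc(Cn2cnc3c(Nc4cccc(OC(F)(F)F)c4)nc(Cl)nc32)cc1`, gives 46.6%; the step of a number 36.9 percentage points lower from compound 1 to compound 3 (beyond the scatter) is large, and the step of a number 27.1 percentage points lower from compound 2 to compound 3 (beyond the scatter) is also beyond the scatter.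

Compound 4, `Nc1ccccc1NC(=O)/C=C/c1ccc(Cn2cnc3c(Nc4ccccc4)nc(Cl)nc32)cc1`, has not yet been measured. It differs from compound 1 in one place: 2-((2-aminophenyl)carbamoyl)ethenyl in place of (2-aminophenyl)carbamoyl on an aromatic carbon. Every measured step changes the group on the ring attached to the anilino nitrogen of the shared core; none touches the amide arm at the other end. Among the measured compounds shown here, no measured step therefore bears directly on the change from compound 1 to compound 4, and the expectation rests on the untouched remainder of the molecule, which is identical in compound 1 and compound 4.

Compound 4 is therefore expected to give about 78%, in the range 55% to 95%. That estimate means a step of a number 5.5 percentage points lower from compound 1 to compound 4 (within the scatter), which is expected to stay within the scatter.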

Compound 4, a percentage reported as inhibition, at one concentration (the size of the read-out at that concentration, not a potency): 30.9%
Beside the measured number, compound 4's estimate is 47.1 percentage points above it; measured number outside the range, below it.
By their numbers in this assay, from the lowest: compound 4; then compound 3; then compounds 2 and 1 (each within the scatter of the next).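

Every earlier step changed the ring on the anilino nitrogen, so the amide arm had not been tested, and this result shows that the arm is not a silent part of the molecule: in this assay, a change at this position alone gives a number 52.6 percentage points lower from compound 1 to compound 4 (beyond the scatter). The group that leaves and the group that enters carry the same counts of hydrogen-bond donors and acceptors and the same six-membered aromatic ring, so they differ by the two extra carbons and the extra double bond of the ethenyl link. Nothing measured here explains why the number falls with this change.

From the compounds shown here alone, whether the fall follows the added length or the double bond stays open, and a saturated two-carbon chain in place of the ethenyl link would help to separate the two. Also open, going by these compounds, is whether the ethenyl arm would give a similar result with the pyridin-2-yl group of compound 2 or the trifluoromethoxy group of compound 3 at the other end of the molecule.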